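The compounds below may be only part of what the source reports. "The series", "measured", "known", "first", "only" and "open" are said of these compounds alone.

Measured so far in a functional assay on HeLa cells (Homo sapiens) for cytotoxicity, read by MTT assay, with a stated time of 48 h; on this read-out lower numbers stand for stronger inhibition and higher numbers for weaker inhibition:
compound 1 `O=C1C(O)=C(C(c2ccccc2)c2c(-c3ccccc3)[nH]c3ccccc23)C(=O)c2ccccc21`: 18800 nM
compound 2 `O=C1C(O)=C(C(c2cccc([N+](=O)[O-])c2)c2c(-c3ccccc3)[nH]c3ccccc23)C(=O)c2ccccc21`: 12500 nM

Compound 2 gives the lowest of the two numbers, but its nearest neighbour is compound 1 and the step of a 1.5-fold lower number from compound 1 to compound 2 (0.18 log units; within the scatter) lies within the scatter, so the two cannot be told apart. Compound 3 `O=C1C(O)=C(C(c2ccc([N+](=O)[O-])cc2)c2c(-c3ccccc3)[nH]c3ccccc23)C(=O)c2ccccc21` differs from compound 2 by 4-nitrophenyl in place of 3-nitrophenyl on a saturated chain carbon bound to an aromatic carbon and a double-bonded ring carbon. For the measured compounds named here, the only measured step, a 1.5-fold lower number from compound 1 to compound 2 (0.18 log units; within the scatter), concerns the nitro group being present at all, not where it sits; no pair of nitro isomers has been compared. No step beyond the scatter is therefore expected. Compound 3 is estimated at 12500 nM, with a range of 5000 nM to 31000 nM. The step this estimate implies, no change at the digits printed from compound 2 to compound 3 (within the scatter), is expected to stay within the scatter.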

Compound 3, half-maximal inhibitory concentration: 6770 nM
Estimate against measurement, compound 3: 1.8-fold (0.27 log units) above, and the stated range covers the measured number.
By their numbers in this assay, from the lowest: compounds 3, 2 and 1 (each within the scatter of the next, the first and the last beyond it).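

In this assay, 4-nitrophenyl in place of 3-nitrophenyl gives a 1.8-fold lower number from compound 2 to compound 3 (0.27 log units; within the scatter) and so the two nitro isomers cannot be told apart. Against the unsubstituted phenyl of compound 1, 4-nitrophenyl gives a 2.8-fold lower number from compound 1 to compound 3 (0.44 log units; beyond the scatter) and this is the first step in the series to clear the scatter. Nothing at hand bears on what lies behind this step. Open, from the compounds shown here alone, is whether the step is particular to nitro: an amine or a carboxylic acid in place of the nitro group would test this.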